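Dropping the Chloro Group from Compound 2

The compounds below may be only part of what the source reports. "The series", "measured", "known", "first", "only" and "open" are said of these compounds alone.

Measured compounds:
compound 1 `COc1cc(C(=O)c2sc(-c3ccc(C)cc3)cc2N)cc(OC)c1OC` — 15 nM
compound 2 `COc1cc(C(=O)c2sc(-c3ccc(Cl)cc3)cc2N)cc(OC)c1OC` — 70 nM
compound 3 `COc1cc(C(=O)c2sc(-c3ccc(I)cc3)cc2N)cc(OC)c1OC` — 150 nM

In a functional assay on CCRF-CEM cells (Homo sapiens) for antiproliferative activity (a lower number here means a stronger inhibitor, a higher number a weaker inhibitor), compound 2 gives 70 nM, the second highest of the three numbers. Its nearest neighbour is compound 3, with a 2.1-fold higher number from compound 2 to compound 3 (0.33 log units; beyond the scatter) marking the gap; compound 1 lies furthest away, as a 4.7-fold higher number from compound 1 to compound 2 (0.67 log units; beyond the scatter) shows. Compound 4 `COc1cc(C(=O)c2sc(-c3ccccc3)cc2N)cc(OC)c1OC` has not yet been measured in this assay. It differs from compound 2 in one place: hydrogen in place of chloro on an aromatic carbon.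

Among the measured compounds shown here, no measured step replaces a substituent with hydrogen, so none bears directly on this change. The three steps that exist all swap one substituent for another at the same position. The methyl compound 1 gives the lowest number, and the numbers rise through chloro to iodo, with a 10-fold higher number from compound 1 to compound 3 (1.00 log units; beyond the scatter) the largest of them. That sequence points toward smaller groups giving lower numbers, but hydrogen lies outside the series, and compound 1, not compound 2, sets the best value, so the expectation for compound 4 is loosely held. A step in this assay of modest size toward a lower number is expected, as a 1.8-fold lower number from compound 2 to compound 4 (0.24 log units; within the scatter) states. Compound 4 is therefore expected to give 40 nM, within 12 nM to 130 nM.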

Compound 4, half-maximal inhibitory concentration: 4.5 nM
Estimate against measurement, compound 4: 8.9-fold (0.95 log units) above, outside the stated range (below it).
By their numbers in this assay, from the lowest: compound 4; then compound 1; then compound 2; then compound 3.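

In this assay the bare phenyl of compound 4 now stands lowest of the four, and the 4-chlorophenyl to phenyl change proves far from neutral: the step is a 16-fold lower number from compound 2 to compound 4 (1.19 log units; beyond the scatter) and the matching loss of iodo gives a 33-fold lower number from compound 3 to compound 4 (1.52 log units; beyond the scatter), both larger than any step seen among the substituted compounds. Methyl, which gave the lowest number so far, also falls short of hydrogen at this place on the ring, with a 3.3-fold lower number from compound 1 to compound 4 (0.52 log units; beyond the scatter) as the gap, so the earlier ranking of three substituents against one another gave way to a picture in which all three go with a higher number than no substituent at all. Nothing available explains why hydrogen stands lowest here.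

Going by these compounds, what remains open is whether any other group at this position, such as fluoro, methoxy, an amine or a carboxylic acid, could match hydrogen or pass it. Four compounds also cannot show whether the order methyl, chloro, iodo reflects a trend that extends to further groups, or whether this order would hold in other cell lines.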